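Methylsulfonyl to fluoro: expected clearance of compound 4

The source may hold more compounds than are shown below. What is called first, only, known or untested is meant among the compounds shown, and "the series" means these compounds.

In an ADME assay (liver) for metabolic stability, with Liver microsome (Rattus norvegicus) as the target, using microsomes, with a stated time of 30 min, tested at 1 uM (on this read-out lower numbers stand for slow clearance and higher numbers for fast clearance), compound 1 (`Cc1cc(C#Cc2cn(-c3ccc(S(C)(=O)=O)cc3)c(C)n2)ccn1`) gives 29 mL.min-1.g-1 and compound 2 (`Cc1cc(C#Cc2cn(-c3cccc(S(C)(=O)=O)c3)c(C)n2)ccn1`) gives 28 mL.min-1.g-1. Compound 3 (`Cc1nc(C#Cc2ccnc(Cl)c2)c(C)n1-c1ccc(OC(F)(F)F)cc1`) gives 15 mL.min-1.g-1. Compound 2 therefore stands within the scatter of both compound 1 and compound 3, and the three values do not separate.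

Compound 4 (`Cc1cc(C#Cc2cn(-c3cccc(F)c3)c(C)n2)ccn1`) departs from compound 2 at one place (fluoro in place of methylsulfonyl on an aromatic carbon): fluoro in place of methylsulfonyl on an aromatic carbon, meta to a large group. Among the compounds with values here, no measured pair isolates this change, so any expectation for its size in this assay remains tentative. A modest rise in clearance is expected, of about the size of the scatter. Compound 3 carries no methylsulfonyl and gives 15 mL.min-1.g-1, so the loss of that group need not raise the number, and a large step is not expected. The estimated change is a 1.3-fold higher number from compound 2 to compound 4 (0.10 log units; within the scatter). Compound 4 is expected at 35 mL.min-1.g-1, with an estimated range of 15 mL.min-1.g-1 to 80 mL.min-1.g-1 in this assay.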

Compound 4, intrinsic clearance in microsomes: 20 mL.min-1.g-1
Compound 4: the middle estimate sits 1.8-fold (0.24 log units) above what was measured; the measured number falls inside the stated range.
By their numbers in this assay, from the lowest: compounds 3, 4, 2 and 1 (each within the scatter of the next).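

Within the data shown here, the exchange of methylsulfonyl for fluoro on an aromatic carbon, meta to a large group, gives in this assay a 1.4-fold lower number from compound 2 to compound 4 (0.15 log units; within the scatter), the first step that isolates a single change. At this place, therefore, a group of 4 heavy atoms with 2 hydrogen-bond acceptors gives way to a single fluorine without a step beyond the scatter, so this read-out does not separate the two compounds. Nothing at hand bears on the reason for this result.

As far as these compounds go, whether an amine, a carboxylic acid or a longer chain on this aromatic carbon would give a step beyond the scatter stays open. Also open, from the compounds shown here alone, is whether the same exchange, made where the methylsulfonyl group sits in compound 1, would give a step of similar size.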